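This account rests on a few compounds, and the source may have more. Where it says the series, first, only, none or still open, it means among the compounds named here.

Measured in a functional assay on blood (Homo sapiens), with a stated time of 60 min, in the presence of a further agent that is not named here; on this read-out higher numbers stand for an effect only at larger amounts of compound and lower numbers for an effect already at smaller amounts:
- compound 1 `O=S(=O)(c1ccc(Oc2ccc(OC(F)(F)F)cc2)cc1)C1CCC2(CCNCC2)C1`: > 15000 nM
- compound 2 `O=S(=O)(c1ccc(Oc2ccc(OC(F)(F)F)cc2)cc1)C1(CO)CCC2(CCNCC2)C1`: > 15000 nM

Neither entry is a number, since both are limits of the assay. Compound 2 stands only at its limit of > 15000 nM. Compound 1 also stands only at a limit, > 15000 nM. Together they make up (the limit of > 15000 nM in this assay, at which 2 of the 2 values shown sit).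

Compound 3 `O=C1CN(C(=O)C2(S(=O)(=O)c3ccc(Oc4ccc(OC(F)(F)F)cc4)cc3)CCC3(CCNCC3)C2)CCN1` differs from compound 2 on a saturated ring carbon: (3-oxopiperazin-1-yl)carbonyl in place of hydroxymethyl on a saturated ring carbon.

Going by the values given here, the only measured step bearing on this change is a step that the two limits leave unreadable from compound 1 to compound 2. It concerns the same kind of ring carbon, but it offers no size or direction to carry over. With so little to go on, a result in this assay close to the limit is expected, and another limit is quite possible. The expected change is an at least 1.5-fold lower number from compound 2 to compound 3 (0.17 log units; that floor lies within the scatter). For compound 3 the estimated value is 10000 nM, with an expected range from 1500 nM to 30000 nM.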

Compound 3, half-maximal effective concentration: 7500 nM
Compound 3: middle estimate off by 1.3-fold (0.12 log units), on the high side, within the range that was stated.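

In this assay, going by these compounds alone, compound 3 gives 7500 nM, the only actual number among the three compounds, which shows that a substituent on this saturated ring carbon can bring the read-out inside the measurable range. Exchanging hydroxymethyl for (3-oxopiperazin-1-yl)carbonyl gives an at least 2.0-fold lower number from compound 2 to compound 3 (0.30 log units; that floor lies within the scatter), and exchanging hydrogen for the same group gives an at least 2.0-fold lower number from compound 1 to compound 3 (0.30 log units; that floor lies within the scatter). Both steps start from limits and are therefore only floors, so their true size cannot be read.

The compounds shown leave open whether the carbonyl or the six-membered ring of the entering group matters more. They also leave open whether a carboxylic acid, an amine or a longer chain on the same ring carbon would give a lower number still.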